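The compounds below may be only part of what the source reports. "The series", "measured", "known", "first", "only" and "open" are said of these compounds alone.

Measured so far, in an assay on HEK293 cells for negative allosteric modulation of metabotropic glutamate receptor 5 (Homo sapiens), read by FLIPR, with a stated time of 1 h; a lower number here means a stronger inhibitor, a higher number a weaker inhibitor:
- compound 1 `O=C(C1CCCC1)N1CCc2nc(C#Cc3ccccc3)sc2C1` gives > 10000 nM, which is a limit of the assay and not a number.
- compound 2 `O=C(c1cccc(Cl)c1)N1CCc2nc(C#Cc3ccccc3)sc2C1` gives > 10000 nM, likewise a limit.

Compound 2 therefore stands at the limit of > 10000 nM in this assay, at which 2 of the 2 values shown sit. Among the compounds with values here, the single measured step, a step that the two limits leave unreadable from compound 1 to compound 2, cannot be read, since both of its ends are limits. Compound 3 `Cc1cccc(C(=O)N2CCc3nc(C#Cc4ccccc4)sc3C2)n1` differs from compound 2 in one place: 6-methylpyridin-2-yl in place of 3-chlorophenyl on a carbonyl carbon. Within the data shown here, no measured step bears on this change, and the one step known gives no size at all. What compound 2 shows is only that its inhibition is weaker than the assay can number. On that basis compound 3 is expected to stay near the same limit, and the estimated step of a number no higher from compound 2 to compound 3 (the limit leaves the size open) is expected to lie within the usual scatter. The estimate for compound 3 in this assay is 10000 nM, in the range 1500 nM to 30000 nM.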

Compound 3, half-maximal inhibitory concentration: > 10000 nM
Compound 3 ended at the assay's limit; the forecaster's own chance of this, stated with the estimate: 65%; the middle value sits exactly at the limit.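

Compound 1, compound 2 and compound 3 all sit at a limit of this assay, so no step among them can be read: the limit of > 10000 nM in this assay, at which 3 of the 3 values shown sit.

The compounds shown leave open whether cyclopentyl, 3-chlorophenyl and 6-methylpyridin-2-yl on the carbonyl carbon differ at all in inhibition.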